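This account rests on a few compounds, and the source may have more. Where it says the series, first, only, none or still open, it means among the compounds named here.

Measured compounds:
Compound 1, `O=[N+]([O-])c1ccc(/C=N/Cc2cccnc2)cc1`, in a functional assay on the whole organism (strain Swiss albino) with Mus musculus as the target, with a stated time of 4 h (on this read-out lower numbers stand for an effect already at smaller amounts and higher numbers for an effect only at larger amounts of compound), gives 100 mg/kg.
Compound 2, `COc1cc(/C=N/Cc2cccnc2)cc(OC)c1OC`, in this assay gives 30 mg/kg.

Among the two numbers in this assay, compound 1 carries the highest one; its nearest neighbour is compound 2, whose number is lower by an amount that lies beyond the usual scatter of repeated measurements. For the measured compounds named here, no single-point step between measured compounds is available in this set, so what the two values show is all that can be said of the pair: compound 2 acts at a smaller amount than compound 1.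

The unmeasured compound 3, `Clc1ccc(/C=N/Cc2cccnc2)cc1`, differs from compound 1 in one place:

chloro in place of nitro on an aromatic carbon

Going by the values given here, no measured step of this kind exists here, and no comparison in the set isolates a chloro in place of a nitro. He therefore expects the step from compound 1 to compound 3 in this assay to be small, a 1.4-fold lower number from compound 1 to compound 3 (0.15 log units; within the scatter), and not clearly beyond the scatter, with a slight lean toward a lower number. For compound 3 in this assay he estimates 70 mg/kg, with a range from 30 mg/kg to 200 mg/kg.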

Compound 3, minimum effective dose: 300 mg/kg
Compound 3: middle estimate off by 4.3-fold (0.63 log units), on the low side, and the stated range ends below it.
By their numbers in this assay, from the lowest: compound 2; then compound 1; then compound 3.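

Read in this assay, chloro in place of nitro brings a 3.0-fold higher number from compound 1 to compound 3 (0.48 log units; beyond the scatter), the first single-point step in the set, and it lies beyond the usual scatter. It shows that this place, an aromatic carbon para to a group of 9 heavy atoms, is not indifferent to what it carries: with the rest of the core of compound 1 unchanged, the swap moves the effect to a larger amount of compound, so within this pair nitro is the group that acts at the smaller dose. The two structures differ in the heavy atoms and hydrogen-bond acceptors counted for each group, but nothing at hand ties the shift to either count or offers any explanation for it.

The compounds shown leave open how an amine, a nitrile or a bromo on this same aromatic carbon would stand against nitro and chloro, and so whether these two groups belong to any wider order. They also leave open whether chloro in place of nitro would bring a step of similar size on a different core.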